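The source may report more compounds than this note shows. Statements on the series, on what has been measured and on what is new or still open speak of the compounds shown alone.

Measured in an ADME assay on the whole organism (plasma, strain CD1) for pharmacokinetics, with Mus musculus as the target, at a dose of 30 mg/kg by the oral route; on this read-out lower numbers stand for lower exposure and higher numbers for higher exposure at the dose given:
- Compound 1 `CCOC(=O)c1c(-c2cccc(-c3ccccc3)c2)[nH]c2cc(OC)ccc2c1=O`: 679 ng.h/mL
- Compound 2 `CCOC(=O)c1c(-c2cccc(OCC)c2)[nH]c2cc(OC)ccc2c1=O`: 1870 ng.h/mL
- Compound 3 `CCCOc1cccc(-c2[nH]c3cc(OC)ccc3c(=O)c2C(=O)OCC)c1`: 610 ng.h/mL

On these numbers, compound 3 shows no clear gap on one side, with a 1.1-fold lower number from compound 1 to compound 3 (0.05 log units; within the scatter), and a clear gap on the other, with a 3.1-fold lower number from compound 2 to compound 3 (0.49 log units; beyond the scatter). The next compound, compound 4 `CCOC(=O)c1c(-c2cccc(Oc3ccccc3)c2)[nH]c2cc(OC)ccc2c1=O`, follows from phenyl in place of propyl on an oxygen on an aromatic ring, which is phenyl in place of propyl on an oxygen on an aromatic ring.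

Going by the values given here, no measured step makes this exact change. The closest evidence is a 3.1-fold lower number from compound 2 to compound 3 (0.49 log units; beyond the scatter), a change on the same oxygen's chain, which was modest. The other two steps replace the phenyl group and point different ways, with a 2.8-fold higher number from compound 1 to compound 2 (0.44 log units; beyond the scatter) and a 1.1-fold lower number from compound 1 to compound 3 (0.05 log units; within the scatter). Together they give no direction for the new change, and modest moves either way remain possible. The expected result is a 1.1-fold higher number from compound 3 to compound 4 (0.06 log units; within the scatter), which means no step beyond the scatter. For compound 4 the estimated value is 700 ng.h/mL, with an expected range from 250 ng.h/mL to 1900 ng.h/mL.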

Compound 4, area under the concentration-time curve: 62.3 ng.h/mL
Beside the measured number, compound 4's estimate is 11-fold (1.05 log units) above it; the measured number lies below the stated range.
By their numbers in this assay, from the lowest: compound 4; then compounds 3 and 1 (each within the scatter of the next); then compound 2.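

In this assay, phenyl on this oxygen brings a much deeper fall than the change from ethyl to propyl had suggested, whether it replaces propyl (a 9.8-fold lower number from compound 3 to compound 4 (0.99 log units; beyond the scatter)) or ethyl (a 30-fold lower number from compound 2 to compound 4 (1.48 log units; beyond the scatter)). The linking oxygen also counts: the phenoxy group of compound 4 does not behave like the phenyl group attached directly to the aromatic carbon in compound 1 (an 11-fold lower number from compound 1 to compound 4 (1.04 log units; beyond the scatter)), so compound 4 ends up the lowest of the four. Nothing available here explains this fall.

The compounds shown leave open whether the fall follows from the aromatic ring itself or simply from the larger group, a question that cyclohexyl on the same oxygen would address. They also leave open whether an amine or a carboxylic acid on the new phenyl ring would change the exposure.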